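A few compounds are considered here, and "the series" means these few. Any claim that something is new, unique, unknown or untested is made for them only; others in the source may bear on it.

Compound 2 `O=c1onc2n1C=CSC2(O)c1ccc(Cl)cc1` gives in a functional assay on A2780/DX3 cells (Homo sapiens) for antiproliferative activity, read by MTT assay, with a stated time of 3 days (on this read-out lower numbers stand for stronger inhibition and higher numbers for weaker inhibition), only the assay limit, > 100000 nM. Compound 1 `CC1=CSC(O)(c2ccccc2)c2noc(=O)n21` likewise stops at the limit in this assay, > 100000 nM. Among the measured compounds shown here, the only evidence is the limit of > 100000 nM in this assay, at which 2 of the 2 values shown sit, so no step between measured compounds can be sized. Compound 3 `O=c1onc2n1C=CSC2(O)c1ccccc1` differs from compound 2 by hydrogen in place of chloro on an aromatic carbon. With compound 2 at the limit > 100000 nM in this assay, no change beyond the scatter is expected from this step. The expected step from compound 2 to compound 3 is a step that the limit leaves unreadable from compound 2 to compound 3. Compound 3 is estimated at 150000 nM, between 50000 nM and 500000 nM, most likely reported again as a limit.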

Compound 3, half-maximal inhibitory concentration: > 100000 nM
Compound 3 gave a limit, no number; the forecaster's own chance of this, stated with the estimate: 85%; the middle value lies beyond the limit too.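

Compound 1, compound 2 and compound 3 all stop at the assay limit, so no step among them can be read: the limit of > 100000 nM in this assay, at which 3 of the 3 values shown sit.

The compounds shown leave open how far either change on the shared core moves activity in this assay.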